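Tert-Butyl on the Cinnamamide Ring of Compound 1

This account rests on a few compounds, and the source may have more. Where it says the series, first, only, none or still open, it means among the compounds named here.

Measured compounds:
compound 1 `O=C(/C=C/c1ccccc1)Nc1ccc2c(c1)COC2=O`: 7240 nM
compound 2 `O=C(/C=C/c1cccc(F)c1)Nc1ccc2c(c1)COC2=O`: 34 nM

Compound 1 stands highest of the two numbers in a functional assay on cells (T-cell, Mus musculus) for inhibition; a lower number here means a stronger inhibitor, a higher number a weaker inhibitor; its nearest neighbour is compound 2, which gives 34 nM, a 210-fold lower number from compound 1 to compound 2 (2.33 log units; beyond the scatter). Compound 3 `CC(C)(C)c1ccc(/C=C/C(=O)Nc2ccc3c(c2)COC3=O)cc1` differs from compound 1 by tert-butyl in place of hydrogen on an aromatic carbon. Among the measured compounds shown here, only one step has been measured, and it concerns a different group at a different place on the same ring, so it bears on compound 3 only loosely: it shows that a single substituent on that ring can move this assay a great deal, but not which way tert-butyl will go. Some lowering is therefore expected for compound 3, with wide uncertainty, a 3.6-fold lower number from compound 1 to compound 3 (0.56 log units; beyond the scatter). Compound 3 is estimated at 2000 nM, within 300 nM to 15000 nM.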

Compound 3, half-maximal inhibitory concentration: 720 nM
Compound 3: the middle estimate sits 2.8-fold (0.44 log units) above what was measured, and the stated range covers the measured number.
By their numbers in this assay, from the lowest: compound 2; then compound 3; then compound 1.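

With tert-butyl on an aromatic carbon para to a large group, the number in this assay falls, a 10-fold lower number from compound 1 to compound 3 (1.00 log units; beyond the scatter), so this place on the ring accepts a substituent of four heavy atoms and the change lowers the number rather than raising it. The earlier step, a 210-fold lower number from compound 1 to compound 2 (2.33 log units; beyond the scatter), concerned fluoro at a different place on the ring and said nothing about this carbon. No measurement shown here accounts for the change seen with tert-butyl.

The compounds shown leave open how methyl, methoxy or an amine on this same carbon would compare with tert-butyl, so a single substituent here gives no trend. They also leave open what fluoro would do on this carbon, and what tert-butyl and fluoro would do together on one ring.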